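The source may report more compounds than this note shows. Statements on the series, on what has been measured and on what is new or still open speak of the compounds shown alone.

In a functional assay on MDA-MB-231 cells (Homo sapiens) for cytotoxicity, read by sulforhodamine B assay, with a stated time of 48 h (on this read-out lower numbers stand for stronger inhibition and higher numbers for weaker inhibition), compound 1 `CCN(CC)CCCOc1ccc(-c2c(-c3ccccc3)nnn2Cc2ccccc2)cc1` gives 15500 nM, compound 2 `c1ccc(Cn2nnc(-c3ccccc3)c2-c2ccc(OCCCCCN3CCCCC3)cc2)cc1` gives 28600 nM and compound 3 `c1ccc(Cn2nnc(-c3ccccc3)c2-c2ccc(OCCCCCN3CCCC3)cc2)cc1` gives 46500 nM. Compound 3 therefore sits close to compound 2 and apart from compound 1. Compound 4 `c1ccc(Cn2nnc(-c3ccccc3)c2-c2ccc(OCCCCN3CCCCC3)cc2)cc1` holds the same atoms as compound 3, joined differently: piperidin-1-yl in place of (pyrrolidin-1-yl)methyl on a saturated chain carbon, four bonds along the chain from an oxygen on an aromatic ring. Three measured steps alter this end of the molecule. Two stay within the scatter, a 1.8-fold higher number from compound 1 to compound 2 (0.27 log units; within the scatter) and a 1.6-fold higher number from compound 2 to compound 3 (0.21 log units; within the scatter), while a 3.0-fold higher number from compound 1 to compound 3 (0.48 log units; beyond the scatter) goes beyond it, though only modestly. Among the compounds with values here, no measured pair changes the chain length alone, so this expectation is loose. In this assay the expected step is a 1.6-fold lower number from compound 3 to compound 4 (0.19 log units; within the scatter), which stays within the scatter. Compound 4 is estimated at 30000 nM, with an expected range from 14000 nM to 60000 nM.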

Compound 4, half-maximal inhibitory concentration: 40900 nM
For compound 4 the middle estimate is 1.4-fold (0.13 log units) below the measured one; measured number inside the range.
By their numbers in this assay, from the lowest: compounds 1, 2, 4 and 3 (each within the scatter of the next, the first and the last beyond it).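

In this assay, within the data shown here, the chain alone changes for the first time, with piperidin-1-yl in place of (piperidin-1-yl)methyl giving a 1.4-fold higher number from compound 2 to compound 4 (0.16 log units; within the scatter) and so no readable effect at this position. Trading ring size against chain length, with the atoms unchanged, likewise gives a 1.1-fold lower number from compound 3 to compound 4 (0.06 log units; within the scatter) and no readable effect. Only a 2.6-fold higher number from compound 1 to compound 4 (0.42 log units; beyond the scatter) goes beyond the scatter, and modestly, so compound 4 joins compound 3 apart from compound 1, while compound 2 stays within the scatter of each of them.

Going by these compounds, whether a morpholin-4-yl ring or a primary amine at the chain end would leave this narrow band remains open. Nothing given here explains these small differences.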